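Reshaping the Piperidine Substituent in a Serotonin Receptor Series

The compounds below may be only part of what the source reports. "The series", "measured", "known", "first", "only" and "open" are said of these compounds alone.

Of the compounds shown here, three with a shared core have been tested in a functional assay on CHO cells for activation of 5-hydroxytryptamine receptor 1D (Homo sapiens), read by GTPgammaS binding; on this read-out lower numbers stand for smaller maximal responses and higher numbers for larger maximal responses. Compound 1 `c1ccc(C2CCCCN2C2CCN(CCCc3c[nH]c4ccc(-n5cnnc5)cc34)CC2)cc1` gives 65%. Compound 2 `CN(Cc1ccccc1)CC1CCN(CCCc2c[nH]c3ccc(-n4cnnc4)cc23)CC1` gives 93%, the highest of the three numbers. Compound 3 `OC[C@H](NC1CCN(CCCc2c[nH]c3ccc(-n4ccnc4)cc23)CC1)c1ccccc1` gives 74%. Compound 2 stands clearly above the rest: its gap to compound 3 lies beyond the scatter, and its gap to compound 1 is wider still.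

Compound 4 `O[C@@H]1Cc2ccccc2[C@H]1NC1CCN(CCCc2c[nH]c3ccc(-n4cnnc4)cc23)CC1` awaits measurement. Against compound 2 the change is (2-hydroxy-2,3-dihydro-1H-inden-1-yl)amino in place of (benzyl(methyl)amino)methyl on a saturated ring carbon. Among the measured compounds shown here, no pair of measured compounds differing in a single place is available, so the size of the step must be judged from the whole set. Compound 3, whose substituent likewise includes an amino link and a hydroxyl, gives 74%, well below compound 2. Compound 4 is therefore estimated to reach 75%, within a range from 60% to 90%. The expected step of a number 18 percentage points lower from compound 2 to compound 4 (beyond the scatter) is a decrease beyond the scatter.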

Compound 4, largest response reached (reported as efficacy), in percent of the reference or control that the assay uses: 75%
Estimate against measurement, compound 4: no gap at the digits printed; the range from low to high includes it.
By their numbers in this assay, from the lowest: compounds 1, 3 and 4 (each within the scatter of the next); then compound 2.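

In this assay, among the compounds shown here, placing (2-hydroxy-2,3-dihydro-1H-inden-1-yl)amino in place of (benzyl(methyl)amino)methyl on a saturated ring carbon gives a number 18 percentage points lower from compound 2 to compound 4 (beyond the scatter) and provides the first single-place comparison in this set, showing that the maximal response responds to what sits at this position. The change is not a simple one: the entering group brings a hydroxyl, hydrogen-bond donors, a five-membered non-aromatic ring and defined stereocentres all at once. No measurement at hand explains the step or assigns it to any one of these features. The compounds shown leave open whether the hydroxyl matters, a question that a methoxy group in its place could help to answer. They also leave open how the other stereoisomers of the entering group would behave.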